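The source may report more compounds than this note shows. Statements on the series, on what has been measured and on what is new or still open speak of the compounds shown alone.

Compound 1 `Nc1ccccc1NC(=O)/C=C/c1ccc(CSc2ccc(F)cc2)cc1` gives 51.2% in a functional assay on A549 cells (Homo sapiens) for inhibition, read by CCK-8 assay, with a stated time of 72 h, tested at 2 uM (a higher number here means more inhibition of growth at the concentration tested, a lower number less inhibition of growth), and stands highest among the three compounds measured. Compound 3 `COC(=O)c1ccccc1SCc1ccc(C(=O)Nc2ccccc2N)cc1` gives 44.7% in this assay, which lies within the scatter of compound 1, whereas compound 2 `Cc1ccc(SCc2ccc(C(=O)Nc3ccccc3N)cc2)cc1` gives 40.5%, a value beyond the scatter below compound 1. Compound 4 `CCc1ccc(SCc2ccc(/C=C/C(=O)Nc3ccccc3N)cc2)cc1` has not been measured; it keeps the core of compound 1 and differs only in the change (ethyl in place of fluoro on an aromatic carbon), the (4-fluorophenyl)sulfanyl becoming a (4-ethylphenyl)sulfanyl group. Among the measured compounds shown here, no measured pair reports such a change, so the step is estimated as none beyond the scatter, a number 2.2 percentage points lower from compound 1 to compound 4 (within the scatter). Compound 4 is therefore expected to give about 49%, between 34% and 64%, in this assay.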

Compound 4, percent growth inhibition at one concentration: 60.7%
Compound 4: the middle estimate sits 11.7 percentage points below what was measured; the range from low to high includes it.
By their numbers in this assay, from the lowest: compounds 2, 3, 1 and 4 (each within the scatter of the next, the first and the last beyond it).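

In this assay, among the compounds shown here, the step from fluoro to ethyl on this aromatic carbon, para to a large group, is the first single change that can be read: a number 9.5 percentage points higher from compound 1 to compound 4 (within the scatter). The position therefore carries either the 4-fluorophenyl or the 4-ethylphenyl group, and this assay does not separate the two. Nothing available bears on the reason for this result. Going by these compounds, whether an amine, a carboxylic acid or a longer chain would read the same here remains open. So does whether ethyl would give a similar step on the core of compound 2.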